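The source may report more compounds than this note shows. Statements on the series, on what has been measured and on what is new or still open speak of the compounds shown alone.

Measured so far in a toxicity assay on L3.6pl cells (Homo sapiens) for inhibition, read by ATP content, with a stated time of 72 h; a lower number here means a stronger inhibitor, a higher number a weaker inhibitor:
- compound 1 `COc1ccccc1C(=O)Nc1ccc(N2CCN(Cc3ccccc3)CC2)cc1C(=O)O`: > 10000 nM
- compound 2 `COc1ccccc1C(=O)Nc1ccc(N2CCN(Cc3ccccn3)CC2)cc1C(=O)O`: > 100000 nM
- compound 3 `COc1ccc(C(=O)Nc2ccc(N3CCCN(c4ncccn4)CC3)cc2C(=O)O)cc1`: > 30000 nM

Each of these values is a limit of this assay, not a number. Compound 2 stands at the limit (the limit of > 100000 nM in this assay, at which 1 of the 3 values shown sits); the two other values are limits as well, at the limit of > 10000 nM in this assay, at which 1 of the 3 values shown sits, and (the limit of > 30000 nM in this assay, at which 1 of the 3 values shown sits). Among the compounds with values here, the only measured step, a step that the two limits leave unreadable from compound 1 to compound 2, is therefore unreadable in size and direction.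

The next compound, compound 4 `COc1ccccc1C(=O)Nc1ccc(N2CCN(CCCc3ccccc3)CC2)cc1C(=O)O`, differs from compound 2 by phenethyl in place of pyridin-2-yl on a saturated chain carbon bound to an amine nitrogen in a ring. Within the data shown here, no measured step bears on this change, and none of the three values gives a readable size to compare with, so no step beyond the scatter is expected in this assay, and a further limit is the likeliest outcome. Compound 4 is estimated at 30000 nM, range 8000 nM to 150000 nM, which means an expected step of an at least 3.3-fold lower number from compound 2 to compound 4 (0.52 log units; beyond the scatter).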

Compound 4, half-maximal inhibitory concentration: > 10000 nM
Compound 4: no number, only a limit (the forecaster's own chance of this, stated with the estimate: 80%); the middle value does not contradict the limit.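

Compound 4 gives only a limit, not a number, and its steps from compound 1 and compound 2 cannot be read. The compounds shown leave open whether any member of this series reaches a measurable value in this assay.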